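Replacing an alkynyl ketone with a fluorobenzyl group

The compounds below may be only part of what the source reports. "The series", "measured", "known", "first", "only" and "open" are said of these compounds alone.

Compound 3 `C#CCCC(=O)CC1CCN(C2CCN(S(=O)(=O)c3c(C)cc(C)cc3C)CC2)CC1` gives the lowest number shown in a functional assay on DLD-1 cells (Homo sapiens) for antiproliferative activity, read by CellTiter-Glo, with a stated time of 72 h (on this read-out higher numbers stand for weaker inhibition and lower numbers for stronger inhibition), namely 3 nM. Compound 1 `Cc1cc(C)c(S(=O)(=O)N2CCC(N3CCC(c4ccccc4)CC3)CC2)c(C)c1` gives 865 nM in this assay. Compound 2 `Cc1cc(C)c(S(=O)(=O)N2CCC(N3CCC(CCC#N)CC3)CC2)c(C)c1` sits at a limit of the assay, > 5000 nM (the limit of > 5000 nM in this assay, at which 1 of the 3 values shown sits). Compound 4 `Cc1cc(C)c(S(=O)(=O)N2CCC(N3CCC(Cc4ccccc4F)CC3)CC2)c(C)c1` differs from compound 3 by 2-fluorophenyl in place of (but-3-yn-1-yl)carbonyl on a saturated chain carbon bound to a saturated ring carbon. The measured steps that bear on this run the other way: a 290-fold lower number from compound 1 to compound 3 (2.46 log units; beyond the scatter), and an at least 5.7-fold higher number from compound 1 to compound 2 (0.76 log units; beyond the scatter). With phenyl on that ring carbon compound 1 gives 865 nM, so compound 4, carrying an aryl group again, is expected to return toward that region. The step of a 230-fold higher number from compound 3 to compound 4 (2.37 log units; beyond the scatter) is therefore expected to be large and toward a higher number. Compound 4 is estimated at 700 nM, within a range of 150 nM to 3000 nM.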

Compound 4, half-maximal inhibitory concentration: 74 nM
Compound 4: the middle estimate sits 9.5-fold (0.98 log units) above what was measured, outside the stated range (below it).
By their numbers in this assay, from the lowest: compound 3; then compound 4; then compound 1. At a limit, above all of these: compound 2.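

A benzyl-type aryl group at this position is far from equivalent to a directly attached phenyl: 2-fluorobenzyl in place of phenyl gives a 12-fold lower number from compound 1 to compound 4 (1.07 log units; beyond the scatter) and so recovers much of the activity. Even so, it does not match the alkynyl ketone, as 2-fluorophenyl in its place gives a 25-fold higher number from compound 3 to compound 4 (1.39 log units; beyond the scatter). Measured from a limit of the assay, the change from cyanomethyl gives an at least 67-fold lower number from compound 2 to compound 4 (1.82 log units; beyond the scatter) and shows that the nitrile chain falls behind the fluorinated aryl group.

The data shown give no measured reason for these gaps. Open, going by these compounds, are whether unsubstituted benzyl would behave like 2-fluorobenzyl, and whether an amine or a carboxylic acid on that chain carbon would approach compound 3.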